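This account rests on a few compounds, and the source may have more. Where it says the series, first, only, none or still open, it means among the compounds named here.

Compound 2 `Cc1nc2c(OCc3ccccc3)cccn2c1CC(=O)O` gives 24% in a functional assay on the whole organism (stomach) for inhibition, with Canis familiaris (Canis lupus familiaris) as the target, at a dose of 5 mg/kg by the intravenous route (a lower number here means a weaker effect, a higher number a stronger effect of the compound at the dose given), the highest of the two numbers recorded, with compound 1 `Cc1nc2c(OCc3ccccc3)cccn2c1C#N` giving 4% and the step from a number 20 percentage points higher from compound 1 to compound 2 (beyond the scatter). Compound 3 `CCCCC(=O)OCc1c(C)nc2c(OCc3ccccc3)cccn12` differs from compound 2 by (butylcarbonyl)oxy in place of carboxy on a saturated chain carbon bound to an aromatic carbon. Among the compounds with values here, no measured step covers this change: the only step known, from compound 1 to compound 2, replaces cyano with carboxymethyl, and leaves the present change untested. He therefore expects no step beyond the scatter, a number 4 percentage points lower from compound 2 to compound 3 (within the scatter), though with wide uncertainty. For compound 3 in this assay the estimate is 20%, in the range from 0% to 45%.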

Compound 3, a percentage reported as inhibition, in the whole organism at one dose (the size of the read-out at that dose, not a potency): 96%
Compound 3: middle estimate off by 76 percentage points, on the low side; the measured number lies above the stated range.
By their numbers in this assay, from the lowest: compound 1; then compound 2; then compound 3.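

In this assay, this saturated chain carbon bound to an aromatic carbon proves far more responsive than the earlier pair showed: (butylcarbonyl)oxy in place of carboxy gives a number 72 percentage points higher from compound 2 to compound 3 (beyond the scatter). Against the nitrile, ((butylcarbonyl)oxy)methyl gives a number 92 percentage points higher from compound 1 to compound 3 (beyond the scatter), well beyond the step seen with carboxymethyl. No evidence here accounts for this jump. From the compounds shown here alone, whether a hydroxy group, an amine or a longer chain on that carbon would hold this level stays open, as does how much of the step depends on the butyl chain itself.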